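A few compounds are considered here, and "the series" means these few. Any claim that something is new, unique, unknown or untested is made for them only; others in the source may bear on it.

Series notes. Compound 1 `Nc1nn2c(O)cc(-c3ccc(F)cc3)nc2c1[N+](=O)[O-]` carries a 4-fluorophenyl on the shared core. In a functional assay on L929 cells (Mus musculus) for inhibition (a higher number here means a weaker inhibitor of growth, a lower number a stronger inhibitor of growth), compound 1 gives > 50 ug/mL, which is a limit of the assay and not a number. Compound 2 `Nc1nn2c(O)cc(CNCCO)nc2c1[N+](=O)[O-]` in this assay gives > 50 ug/mL, likewise a limit. Compound 3 `Nc1nn2c(O)cc(CNC(N)SCc3ccccc3)nc2c1[N+](=O)[O-]` in this assay gives > 50 ug/mL, again a limit. Within the data shown here, the one step between measured neighbours, a step that the two limits leave unreadable from compound 1 to compound 2, cannot be sized because both of its ends sit at the limit of > 50 ug/mL in this assay, at which 3 of the 3 values shown sit.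

Compound 4 `CCSC(N)NCc1cc(O)n2nc(N)c([N+](=O)[O-])c2n1` differs from compound 1 as follows: ((amino(ethylsulfanyl)methyl)amino)methyl in place of 4-fluorophenyl on an aromatic carbon. Among the measured compounds shown here, the only measured step that bears on this change is a step that the two limits leave unreadable from compound 1 to compound 2, and it is unreadable. Compound 3 and compound 4 share a chain of the same make-up, an aminomethyl linker carrying an amino group and a sulfanyl group, differing only in what sits on the sulfur. For the measured compounds named here, no measured step in this small set gives a direction, so the expectation for compound 4 in this assay is no step beyond the scatter, the expected step being a step that the limit leaves unreadable from compound 1 to compound 4. Compound 4 is therefore estimated at 80 ug/mL, in the range 40 ug/mL to 200 ug/mL, most probably reported once more as a limit rather than a number.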

Compound 4, concentration for 50% growth inhibition: > 50 ug/mL
Compound 4 was reported as a limit; the forecaster's own chance of this, stated with the estimate: 85%; the middle value lies beyond the limit too.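

Compound 4, like compound 1, compound 2 and compound 3, is reported only as a limit, so none of the steps joining compound 4 to these compounds can be read: the limit of > 50 ug/mL in this assay, at which 4 of the 4 values shown sit.

The compounds shown leave open whether any group at this place on the shared core gives a numerical value in this assay, and how the 4-fluorophenyl and the open chains rank against each other.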